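Three fluorophenyl hydrazones and a dibromo-hydroxyphenyl newcomer

The source may report more compounds than this note shows. Statements on the series, on what has been measured and on what is new or still open speak of the compounds shown alone.

Measured compounds:
- compound 1 `O=C(CSc1nnc(-c2ccncc2)o1)N/N=C/c1ccc(F)cc1` — 170000 nM
- compound 2 `O=C(CSc1nnc(-c2ccncc2)o1)N/N=C/c1cccc(F)c1` — 205000 nM
- compound 3 `O=C(CSc1nnc(-c2ccncc2)o1)N/N=C/c1ccccc1F` — 142000 nM

Three compounds sharing one core were tested in an ADME assay on NIH3T3 cells (Mus musculus) for cytotoxicity, read by MTT assay, with a stated time of 24 h; on this read-out higher numbers stand for weaker inhibition and lower numbers for stronger inhibition. Compound 1 gives 170000 nM in this assay, the second highest of the three numbers. Its neighbours lie close on either side: a 1.2-fold higher number from compound 1 to compound 2 (0.08 log units; within the scatter) and a 1.2-fold lower number from compound 1 to compound 3 (0.08 log units; within the scatter), and between the other two, a 1.4-fold lower number from compound 2 to compound 3 (0.16 log units; within the scatter). All three steps fall within the scatter, so nothing separates these compounds on this read-out.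

Compound 4 `O=C(CSc1nnc(-c2ccncc2)o1)N/N=C/c1cc(Br)cc(Br)c1O` is not yet measured in this assay. It differs from compound 1 in one place: 3,5-dibromo-2-hydroxyphenyl in place of 4-fluorophenyl on a carbon with a double bond to nitrogen The measured steps all concern moving a fluorine around the phenyl ring, and none of them touches a change of the kind that enters here, so none bears directly on it. Going by the values given here, the only guidance is that the common core has so far kept every number within the scatter of compound 1.

Compound 4 is therefore estimated in this assay at 120000 nM, with a range from 35000 nM to 300000 nM. This expected step, a 1.4-fold lower number from compound 1 to compound 4 (0.15 log units; within the scatter), is given wide room for the untested substitution.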

Compound 4, half-maximal inhibitory concentration: 190000 nM
Estimate against measurement, compound 4: 1.6-fold (0.20 log units) below; the measured number falls inside the stated range.
By their numbers in this assay, from the lowest: compounds 3, 1, 4 and 2 (each within the scatter of the next).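

Replacing 4-fluorophenyl with 3,5-dibromo-2-hydroxyphenyl takes this position beyond a shift of fluorine, yet this assay does not separate the new compound from the others (a 1.1-fold higher number from compound 1 to compound 4 (0.05 log units; within the scatter); a 1.3-fold higher number from compound 3 to compound 4 (0.13 log units; within the scatter); a 1.1-fold lower number from compound 2 to compound 4 (0.03 log units; within the scatter)). On the carbon with a double bond to nitrogen, then, a ring carrying two bromines and a hydroxyl gives a number that cannot be told apart from those of the three fluorophenyl compounds. No evidence is available to explain this result.

From the compounds shown here alone, it remains open whether an amine, a carboxylic acid or a longer chain on this carbon would give a step beyond the scatter. All four compounds share one core, so they show nothing about a change made anywhere else in the structure.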